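Working notes: fluorophenyl for methoxyphenyl, compound 2 to compound 4

The compounds below may be only part of what the source reports. "The series", "measured", "known", "first", "only" and "open" are said of these compounds alone.

Measured so far, all in a functional assay on MCF7 cells (Homo sapiens) for antiproliferative activity, read by MTT assay, with a stated time of 72 h; a lower number here means a stronger inhibitor, a higher number a weaker inhibitor:
- compound 1 `CCOc1ccccc1OCCSC(=S)N[C@H]1CCOC1=O`: compound 1 gives > 64000 nM, a limit of the assay.
- compound 2 `COc1ccccc1/C=C/C(=O)c1ccc(OCC(=O)N[C@H]2CCOC2=O)cc1`: compound 2 gives > 64000 nM, also a limit.
- compound 3 `O=C(CNc1ccc(F)cc1)N[C@H]1CCOC1=O`: compound 3 gives > 64000 nM, again a limit.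

Compound 2 thus stands at the limit itself, and no value in this set is a number; (the limit of > 64000 nM in this assay, at which 3 of the 3 values shown sit). Going by the values given here, no step between measured compounds can be drawn from it. Compound 4 `O=C(COc1ccc(C(=O)/C=C/c2ccc(F)cc2)cc1)N[C@H]1CCOC1=O` follows from compound 2 by 4-fluorophenyl in place of 2-methoxyphenyl on a double-bonded chain carbon bound to a double-bonded chain carbon. With every value sitting at the limit, no direction for this change is supported; the step in this assay is expected to be none beyond the scatter, and a limit is again the most likely outcome. For compound 4 the estimate is 80000 nM, between 20000 nM and 300000 nM. The expected step that the limit leaves unreadable from compound 2 to compound 4 is accordingly flat.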

Compound 4, half-maximal inhibitory concentration: > 64000 nM
Compound 4: only a limit was reported; the forecaster's own chance of this, stated with the estimate: 85%; the middle value is on the limit's open side.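

In this assay compound 4 gives > 64000 nM, a limit of the assay. Going by these compounds alone, compound 2 gives > 64000 nM, also a limit, and no step between compound 2 and compound 4 can be read. The compounds shown leave open whether any structure of this kind reaches a measurable value in this assay: the limit of > 64000 nM in this assay, at which 4 of the 4 values shown sit.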